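This account rests on a few compounds, and the source may have more. Where it says the series, first, only, none or still open, it means among the compounds named here.

Three measured compounds share one core: compound 1 `C=C(C)c1cn(-c2cccc(C(=O)/C=C/c3ccc(O)c(OC)c3)c2)nn1`, compound 2 `COc1cc(/C=C/C(=O)c2cccc(-n3cc(-c4ccccc4)nn3)c2)ccc1O` and compound 3 `COc1cc(/C=C/C(=O)c2cccc(-n3cc(-c4ccc(F)cc4)nn3)c2)ccc1O`. In a functional assay on RAW264.7 cells (Mus musculus) for inhibition, with a stated time of 4 days (on this read-out lower numbers stand for stronger inhibition and higher numbers for weaker inhibition), compound 1 gives 9790 nM, compound 2 gives 16800 nM and compound 3 gives 6450 nM. Compound 3 stands lowest of the three numbers, though its gap to compound 1 lies within the scatter; only a 2.6-fold lower number from compound 2 to compound 3 (0.42 log units; beyond the scatter) lies beyond it. Compound 4 `COc1cc(/C=C/C(=O)c2cccc(-n3cc(-c4ccc(C)cc4)nn3)c2)ccc1O` differs from compound 3 in one place: methyl in place of fluoro on an aromatic carbon. Among the measured compounds shown here, the measured steps that bear on this are a 2.6-fold lower number from compound 2 to compound 3 (0.42 log units; beyond the scatter) and a 1.5-fold lower number from compound 1 to compound 3 (0.18 log units; within the scatter), both replacing a group at the same place; no step exchanging fluoro for methyl exists. The change is therefore expected to give a 1.3-fold higher number from compound 3 to compound 4 (0.12 log units; within the scatter), nothing beyond the scatter. Compound 4 is estimated at 8500 nM, ranging from 3500 nM to 20000 nM.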

Compound 4, half-maximal inhibitory concentration: 15400 nM
Estimate against measurement, compound 4: 1.8-fold (0.26 log units) below; measured number inside the range.
By their numbers in this assay, from the lowest: compounds 3, 1, 4 and 2 (each within the scatter of the next, the first and the last beyond it).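

The identity of the group on this carbon matters in this assay: exchanging fluoro for methyl gives a 2.4-fold higher number from compound 3 to compound 4 (0.38 log units; beyond the scatter), so the two are not interchangeable here. Methyl does not separate from hydrogen (a 1.1-fold lower number from compound 2 to compound 4 (0.04 log units; within the scatter)), and 4-methylphenyl does not separate from 1-methylethenyl (a 1.6-fold higher number from compound 1 to compound 4 (0.20 log units; within the scatter)), so among hydrogen, fluoro and methyl only fluoro stands apart from hydrogen. Nothing shown explains this difference. From the compounds shown here alone, whether a chloro, methoxy or amino group on this carbon would track fluoro or methyl remains open.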